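The source may hold more compounds than are shown below. What is called first, only, known or untested is meant among the compounds shown, and "the series" means these compounds.

Going by the values given here, compound 1 `COc1ccc(-c2nc(C)c(C(=O)CSc3nc(-c4cccc(OC)c4)c(C#N)c(=O)[nH]3)s2)cc1` gives 15300 nM in a functional assay on U-87MG ATCC cells for antiproliferative activity against U-87 MG (Homo sapiens), read by MTT assay, with a stated time of 48 h (a lower number here means a stronger inhibitor, a higher number a weaker inhibitor), the lowest number among the three compounds measured so far. Compound 2 `COc1cccc(-c2nc(SCC(=O)c3sc(-c4ccccc4)nc3C)[nH]c(=O)c2C#N)c1` gives 59700 nM and compound 3 `COc1cccc(-c2nc(SCC(=O)c3sc(-c4ccc(Cl)cc4)nc3C)[nH]c(=O)c2C#N)c1` gives 41000 nM. The next compound, compound 4 `COc1ccc(-c2nc(C)c(C(=O)CSc3nc(-c4cccc(Cl)c4)c(C#N)c(=O)[nH]3)s2)cc1`, turns the 3-methoxyphenyl of compound 1 into 3-chlorophenyl, with chloro in place of methoxy on an aromatic carbon.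

Among the compounds with values here, no measured compound shows a change at that group, since compound 2 and compound 3 both keep the 3-methoxyphenyl and differ from compound 1 at its other methoxy group. Hydrogen at that other place gave a 3.9-fold higher number from compound 1 to compound 2 (0.59 log units; beyond the scatter), and chloro there gave a 2.7-fold higher number from compound 1 to compound 3 (0.43 log units; beyond the scatter), both modest. Between those two replacements the data show a 1.5-fold lower number from compound 2 to compound 3 (0.16 log units; within the scatter).

Within the data shown here, the nearest precedent is therefore the same exchange at a different place, and it is only a loose guide. Taking compound 3 as that guide, with a 2.7-fold higher number from compound 1 to compound 3 (0.43 log units; beyond the scatter), a small move toward a higher number is expected in this assay, though the direction is not secure. The expected step is a 1.7-fold higher number from compound 1 to compound 4 (0.23 log units; within the scatter). For compound 4 the estimate is 26000 nM, with an expected range from 9000 nM to 70000 nM.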

Compound 4, half-maximal inhibitory concentration: 78900 nM
Compound 4: middle estimate off by 3.0-fold (0.48 log units), on the low side; the whole stated range lies below it.
By their numbers in this assay, from the lowest: compound 1; then compounds 3, 2 and 4 (each within the scatter of the next).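

Going by these compounds alone, compound 4 gives the first reading at the 3-methoxyphenyl group itself: exchanging it for 3-chlorophenyl produces a 5.2-fold higher number from compound 1 to compound 4 (0.71 log units; beyond the scatter) in this assay, so this position does respond to the change, and the response lies beyond the scatter. The same exchange at the other methoxy group of compound 1 gave a 2.7-fold higher number from compound 1 to compound 3 (0.43 log units; beyond the scatter), so in both places where chloro takes the place of methoxy the number rises, and no compound shown goes against this within that pair of exchanges. The data offer no measurement that would explain the step at this position, which therefore stands as an observation only.

With only methoxy and chloro shown on this aromatic carbon, the compounds leave open whether the higher number follows from losing the methoxy group or from gaining the chloro group, a question that plain hydrogen at this place would help to settle. They also leave open how an amine, a hydroxyl group or a longer chain such as ethoxy would read there in this assay, and whether any group at this place could give a lower number than compound 1 does.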